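Replacing methoxy with fluoro in compound 3

The source may report more compounds than this note shows. Statements on the series, on what has been measured and on what is new or still open speak of the compounds shown alone.

Tested in a functional assay on HL-60 cells (Homo sapiens) for inhibition, read by CCK-8 assay, with a stated time of 48 h, tested at 20 uM; a higher number here means more inhibition of growth at the concentration tested, a lower number less inhibition of growth:
- Compound 1 `N#C/C(=C\c1ccccc1OS(=O)(=O)c1ccc(F)cc1)C(=O)Nc1nnc(Cc2ccccc2)s1`: 22%
- Compound 2 `Cc1ccc(S(=O)(=O)Oc2ccccc2/C=C(\C#N)C(=O)Nc2nnc(Cc3ccc(Cl)cc3)s2)cc1`: 15%
- Compound 3 `COc1ccc(S(=O)(=O)Oc2ccccc2/C=C(\C#N)C(=O)Nc2nnc(Cc3ccc(Cl)cc3)s2)cc1`: 99%

Among the three, compound 3 stands highest at 99%, beyond the scatter from both others. Compound 4 `N#C/C(=C\c1ccccc1OS(=O)(=O)c1ccc(F)cc1)C(=O)Nc1nnc(Cc2ccc(Cl)cc2)s1` differs from it in one place: fluoro in place of methoxy on an aromatic carbon, with fluoro in place of methoxy on an aromatic carbon, para to a large group. Within the data shown here, the one measured step at this place is large: a number 84 percentage points higher from compound 2 to compound 3 (beyond the scatter). Compound 1, which carries the same fluoro group but differs elsewhere, gives only 22%. A large fall in this assay is therefore expected, though the size remains uncertain. The expected change is a number 64 percentage points lower from compound 3 to compound 4 (beyond the scatter). For compound 4 the estimated value is 35%, with an expected range from 10% to 85%.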

Compound 4, percent growth inhibition at one concentration: 20%
Compound 4: middle estimate off by 15 percentage points, on the high side; measured number inside the range.
By their numbers in this assay, from the lowest: compounds 2, 4 and 1 (each within the scatter of the next); then compound 3.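

In this assay, the drop of a number 79 percentage points lower from compound 3 to compound 4 (beyond the scatter) shows that the high inhibition is not kept when 4-methoxyphenyl becomes 4-fluorophenyl. Fluoro and methyl at this place cannot be told apart, at a number 5 percentage points higher from compound 2 to compound 4 (within the scatter), and with fluoro in place, chloro in place of hydrogen on an aromatic carbon makes no clear difference, at a number 2 percentage points lower from compound 1 to compound 4 (within the scatter). Nothing available here explains why methoxy alone stands apart among these groups.

Going by these compounds, whether an amine or an ethoxy group at this place would match methoxy remains open. So does whether the methoxy result holds without the chloro.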